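The source may hold more compounds than are shown below. What is called first, only, known or untested is meant among the compounds shown, and "the series" means these compounds.

Measured compounds:
Compound 1 `O=C(NO)c1ccc(-c2cn([C@H]3C[C@@H](CO)N(CCCc4ccccc4)C3)nn2)cc1` — < 10%
Compound 2 `O=C(NO)c1ccc(-c2cn([C@@H]3C[C@H](CO)N(CCCc4ccccc4)C3)nn2)cc1` — 15%
Compound 3 `O=C(NO)c1ccc(-c2cn([C@@H]3C[C@@H](C(=O)O)N(CCCc4ccccc4)C3)nn2)cc1` — 14%

All three were tested in an assay on Sf9 cells for inhibition of histone deacetylase 11 (Homo sapiens), read by fluorescence, tested at 0.5 uM; a lower number here means less inhibition, a higher number more inhibition at the concentration tested (going by the name of the read-out). Compound 1 gives < 10%, which is a limit of the assay rather than a number. Compound 2 gives 15%. Compound 3 gives 14%, a value that differs from the number for compound 2 only within the scatter. For the measured compounds named here, the one step between measured compounds that differ in a single place is a number at least 5 percentage points higher from compound 1 to compound 2 (that floor lies within the scatter), and it concerns a change in configuration only, not a change of group.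

The unmeasured compound 4 `O=C(NO)c1ccc(-c2cn([C@@H]3C[C@@H](CO)N(CCCc4ccccc4)C3)nn2)cc1` is reached from compound 3 by hydroxymethyl in place of carboxy on a saturated ring carbon. Going by the values given here, no measured pair shows what this exchange does: compounds 1 and 2 carry a hydroxymethyl group and compound 3 a carboxy group, but they also differ in configuration, so their values cannot be read as the effect of the group alone. Both groups are present in compounds whose numbers sit close together, and the configuration step was small. The expectation for compound 4 is therefore a step of no change at the digits printed from compound 3 to compound 4 (within the scatter), within the scatter, and compound 4 is estimated at 14% with a range from 5% to 25%.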

Compound 4, a percentage reported as inhibition, at one concentration (the size of the read-out at that concentration, not a potency): 14%
Estimate against measurement, compound 4: no gap at the digits printed; the measured number falls inside the stated range.
By their numbers in this assay, from the lowest: compounds 3, 4 and 2 (each within the scatter of the next). At a limit, below all of these: compound 1.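

In this assay, for the compounds shown here, the step of no change at the digits printed from compound 3 to compound 4 (within the scatter) is the first comparison in which hydroxymethyl replaces carboxy on this saturated ring carbon while the configuration stays the same, and it shows no separation between the two groups at this position. Compound 4 also links the earlier hydroxymethyl compounds through changes in a single stereocentre, giving a number 1 percentage points lower from compound 2 to compound 4 (within the scatter) and a number at least 4 percentage points higher from compound 1 to compound 4 (that floor lies within the scatter), so neither comparison shows a configuration effect beyond the usual scatter. Compound 1 stands at a limit of the assay, so its step gives only a floor: the limit of < 10% in this assay, at which 1 of the 4 values shown sits.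

The compounds shown leave open what an amine or a longer chain such as hydroxyethyl would do on this ring carbon, and whether carboxy gives a similar reading in the other configurations. All these readings come from a single concentration, so they do not tell how potency differs across the set.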